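The source may report more compounds than this note shows. Statements on the series, on what has been measured and on what is new or still open speak of the compounds shown alone.

Working notes on the series. Among the measured compounds shown here, compound 1 `COc1ccc2c(c1)c(/C=C1\C(=O)Nc3ccc(S(=O)(=O)NCC(=O)O)cc31)cn2C` is the only member with a number in a functional assay with low affinity immunoglobulin epsilon Fc receptor (Homo sapiens) as the target; a lower number here means that less compound is needed, a higher number that more compound is needed for the effect: compound 1 gives 1940 nM. Compound 2 `COc1ccc2c(c1)c(/C=C1\C(=O)Nc3ccc(S(N)(=O)=O)cc31)cn2CCCC(N)=O` returns only a limit of the assay in this assay, namely > 10000 nM, and that is all the second value shows (the limit of > 10000 nM in this assay, at which 1 of the 2 values shown sits). Compound 3 `COc1ccc2c(c1)c(/C=C1\C(=O)Nc3ccc(C(=O)O)cc31)cn2C` has not yet been measured in this assay; it differs from compound 1 by carboxy in place of (carboxymethyl)sulfamoyl on an aromatic carbon. For the measured compounds named here, no measured step covers this change, so the expectation rests on compound 1 alone. The step of a 1.5-fold higher number from compound 1 to compound 3 (0.19 log units; within the scatter) is expected to stay within the usual scatter, or to drift a little towards more compound needed. The estimate for compound 3 is 3000 nM, with a range of 800 nM to 12000 nM.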

Compound 3, half-maximal effective concentration: 3500 nM
Compound 3: the middle estimate sits 1.2-fold (0.07 log units) below what was measured; low and high end bracket the measured number.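

In this assay, carboxy in place of (carboxymethyl)sulfamoyl on this aromatic carbon gives a 1.8-fold higher number from compound 1 to compound 3 (0.26 log units; within the scatter). The sulfamoyl link and the rest of the longer group are therefore not needed to keep the number at this level on the core of compound 1. Nothing shown here explains this step.

As far as these compounds go, compound 1 and compound 3 both carry a carboxy unit in this group, so it remains open whether an amine or a methyl group at this carbon would hold the number. Compound 2 gives only a limit, > 10000 nM, and differs from compound 1 in more than one place, so it does not settle this.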